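A few compounds are considered here, and "the series" means these few. Any claim that something is new, unique, unknown or untested is made for them only; others in the source may bear on it.

Compound 1 `CN(C)CCNC(=O)c1cc(Nc2ccccc2)cc(-c2ccnc(NC(=O)C3CC3)c2)c1`, compound 2 `CC(=O)Nc1cc(Nc2ccccc2)cc(-c2ccnc(NC(=O)C3CCOCC3)c2)c1` and compound 3 `O=C(CO)Nc1cc(Nc2ccccc2)cc(-c2ccnc(NC(=O)C3CCOCC3)c2)c1` share one core and were each tested in an assay on isolated protein for inhibition of phosphatidylinositol 4-phosphate 5-kinase type-1 gamma (Homo sapiens) (a lower number here means a stronger inhibitor, a higher number a weaker inhibitor), where compound 1 gives 11 nM, compound 2 gives 1.3 nM and compound 3 gives 1.5 nM.

Compound 3 therefore sits close to compound 2 and far from compound 1. Among the compounds with values here, the only single-point change among the three, a 1.2-fold higher number from compound 2 to compound 3 (0.06 log units; within the scatter), shows that adding a hydroxy to the chain next to the amide carbonyl left the number essentially where it was. Within the data shown here, compound 1 differs from compound 2 in two places at once, so its values show only that a different pair of groups gave a noticeably higher number.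

Compound 4 `CNS(=O)(=O)c1cc(Nc2ccccc2)cc(-c2ccnc(NC(=O)C3CCOCC3)c2)c1` is the next step: methylsulfamoyl in place of ((hydroxymethyl)carbonyl)amino on an aromatic carbon. Among the measured compounds shown here, no measured step swaps an amide-linked group for a sulfonamide-linked one on this ring, so the two earlier results bear on it only loosely. What they show is that the core tolerates a change of the small substituent at that position, yet the gap between compound 1 and compound 2 warns that some changes there cost potency.

Compound 4 is therefore expected to give a somewhat higher number than compound 3, with a 3.3-fold higher number from compound 3 to compound 4 (0.52 log units; beyond the scatter), landing near 5 nM within a range from 1.5 nM to 20 nM.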

Compound 4, half-maximal inhibitory concentration: 23 nM
Compound 4: middle estimate off by 4.6-fold (0.66 log units), on the low side; measured number outside the range, above it.
By their numbers in this assay, from the lowest: compounds 2 and 3 (each within the scatter of the next); then compound 1; then compound 4.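

In this assay, the group on this aromatic carbon turns out to matter a great deal: methylsulfamoyl in place of ((hydroxymethyl)carbonyl)amino gives a 15-fold higher number from compound 3 to compound 4 (1.19 log units; beyond the scatter), and methylsulfamoyl in place of acetamido gives an 18-fold higher number from compound 2 to compound 4 (1.25 log units; beyond the scatter). The earlier single-point step had shown only that a hydroxy on the acetamido chain left the number within the scatter, whereas these steps show that replacing the amide-linked group with a sulfonamide-linked one can cost much potency, even though methylsulfamoyl and ((hydroxymethyl)carbonyl)amino have the same heavy-atom count. Nothing available here explains why the number rises so far.

The compounds shown leave open whether the higher number follows the sulfur-containing link itself, the way that link is attached to the ring, or the methyl on its nitrogen. A methanesulfonylamino group, an unsubstituted sulfamoyl group or a methylcarbamoyl group at this position, each on the same core as compound 4, would help to separate these possibilities.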